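The compounds below may be only part of what the source reports. "The series", "measured", "known", "first", "only" and "open" are said of these compounds alone.

Measured compounds:
compound 1 `CCCCCn1c(SCc2cc([N+](=O)[O-])ccc2OC)nc2cc(NC(=O)NC(C)(C)C)ccc21` — 880 nM
compound 2 `COc1ccc([N+](=O)[O-])cc1CSc1nc2cc(NC(=O)NC(C)(C)C)ccc2n1Cc1ccccc1` — 160 nM
compound 3 `CCCn1c(SCc2cc([N+](=O)[O-])ccc2OC)nc2cc(NC(=O)NC(C)(C)C)cc(C(=O)OC)c21` — 280 nM

In an assay on isolated protein for inhibition of Gonadotropin-releasing hormone receptor (Rattus norvegicus) (a higher number here means a weaker inhibitor, a lower number a stronger inhibitor), compound 3 gives 280 nM, the second highest of the three numbers; compound 2 sits within the scatter of it, while compound 1 lies beyond the scatter on the weaker side. Within the data shown here, the single measured step, a 5.5-fold lower number from compound 1 to compound 2 (0.74 log units; beyond the scatter), concerns the group on a saturated chain carbon bound to an aromatic nitrogen and does not touch the change considered here.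

Compound 4 `CCCn1c(SCc2cc([N+](=O)[O-])ccc2OC)nc2cc(NC(=O)NC(C)(C)C)cc(C(=O)NC)c21` differs from compound 3 by methylamino in place of methoxy on a carbonyl carbon. Among the measured compounds shown here, no measured pair shows this exchange, so no step beyond the scatter is expected; the estimated step is a 1.1-fold lower number from compound 3 to compound 4 (0.05 log units; within the scatter). Compound 4 is therefore estimated at 250 nM, with a range from 100 nM to 700 nM.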

Compound 4, half-maximal inhibitory concentration: 23 nM
Compound 4: the middle estimate sits 11-fold (1.04 log units) above what was measured, outside the stated range (below it).
By their numbers in this assay, from the lowest: compound 4; then compounds 2 and 3 (each within the scatter of the next); then compound 1.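

On a carbonyl carbon whose other neighbour is an aromatic carbon, methylamino in place of methoxy gives a 12-fold lower number from compound 3 to compound 4 (1.09 log units; beyond the scatter) in this assay and sets compound 4 apart from the other compounds. The earlier compounds shown here showed no change at this place; here, a swap of equal heavy-atom count, with one hydrogen-bond acceptor out and one hydrogen-bond donor in, is enough for a large step. Nothing available explains the size of this step.

Open, from the compounds shown here alone, is how amino, dimethylamino or a longer chain on the amide nitrogen would compare with methylamino on this carbonyl carbon, and where a carboxylic acid would fall. Also open, going by these compounds, is whether the step carries over when the group on the aromatic nitrogen is a benzyl.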